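Swapping chloro for methyl on an alkoxybenzoic acid side chain

The source may report more compounds than this note shows. Statements on the series, on what has been measured and on what is new or still open speak of the compounds shown alone.

Measured compounds:
- compound 1, `Cc1c(OCCCCOc2ccc(C(=O)O)cc2Cl)ccc(C(=O)CC2CCCC2)c1O`: 21%
- compound 2, `CCC(=O)c1ccc(OCCCCOc2ccc(F)c(C(=O)O)c2)c(C)c1O`: 35%
- compound 3, `CCCC(=O)c1ccc(OCCCCOc2cc(C(=O)O)ccc2OC)c(C)c1O`: 1%

The three compounds were tested in an ADME assay (liver) for metabolic stability, with Liver microsome (Rattus norvegicus) as the target, read by LC-MS, using microsomes and NADPH, with stated times of 5 min and 60 min, tested at 4 uM; on this read-out lower numbers stand for a less stable compound and higher numbers for a more stable compound. Compound 1 holds the second highest of the three numbers: compound 2 lies above it by a margin beyond the scatter, and compound 3 lies below it by a larger margin, also beyond the scatter.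

Compound 4, `Cc1cc(C(=O)O)ccc1OCCCCOc1ccc(C(=O)CC2CCCC2)c(O)c1C`, is not yet measured. It differs from compound 1 in one place: methyl in place of chloro on an aromatic carbon. For the measured compounds named here, no pair of measured compounds shows this particular change, so no measured step guides the expectation. Given that, the step from compound 1 to compound 4 in this assay is expected to be small, a number 4 percentage points lower from compound 1 to compound 4 (within the scatter), likely within the scatter. Compound 4 is thus estimated at 17%, with a range from 5% to 32%.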

Compound 4, percent of the compound remaining: 59%
Beside the measured number, compound 4's estimate is 42 percentage points below it; measured number above the stated range.
By their numbers in this assay, from the lowest: compound 3; then compound 1; then compound 2; then compound 4.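

Placing methyl where chloro stood, ortho to a large group and meta to a carboxy group, gives in this assay a number 38 percentage points higher from compound 1 to compound 4 (beyond the scatter). So this single position matters on this read-out, even though one heavy atom replaces one heavy atom and the counts of hydrogen-bond donors and acceptors stay the same, something the earlier compounds, which differ in more than one place, could not show. Nothing at hand says why the number rises.

From the compounds shown here alone, whether a nitrile or an amine at this place would behave like methyl remains open. So does whether the same swap carries over to compounds with a shorter ketone chain.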